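The source may hold more compounds than are shown below. What is called first, only, known or untested is meant among the compounds shown, and "the series" means these compounds.

Working notes on the series. Of the compounds shown here, three have been measured in a functional assay on MCF7 cells (Homo sapiens) for antiproliferative activity, read by MTT assay, with a stated time of 48 h, tested at 25 uM; on this read-out lower numbers stand for a stronger effect and higher numbers for a weaker effect at the one concentration tested. Compound 1 `OC(CCn1nc2c(Br)c(Br)c(Br)c(Br)c2n1)c1cccc(Br)c1` gives 106%. Compound 2 `COc1cccc(C(O)CCn2nc3c(Br)c(Br)c(Br)c(Br)c3n2)c1` gives 96%. Compound 3 `C[C@@H](O)CCn1nc2c(Br)c(Br)c(Br)c(Br)c2n1` gives 77%. Among these three numbers compound 2 stands second highest. Within the data shown here, its nearest neighbour is compound 1, and the only single-point step so far, methoxy in place of bromo on an aromatic carbon, gives a number 10 percentage points lower from compound 1 to compound 2 (within the scatter). Among the measured compounds shown here, compound 3 lies furthest from compound 2, and its number is lower than that of compound 2 beyond the scatter; no single-point step joins these two.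

Compound 4 `OC(CCn1nc2c(Br)c(Br)c(Br)c(Br)c2n1)c1ccccc1` is still to be measured in this assay. It differs from compound 2 in one place: hydrogen in place of methoxy on an aromatic carbon. For the measured compounds named here, the one measured step that bears on this position is the exchange of bromo for methoxy, and that step, a number 10 percentage points lower from compound 1 to compound 2 (within the scatter), stayed within the scatter. Because a number 10 percentage points lower from compound 1 to compound 2 (within the scatter) showed no change beyond the scatter when the group on this aromatic carbon was exchanged, no step beyond the scatter is expected here either, in either direction. Compound 4 is therefore expected to give 100%, with a range from 85% to 115%. The expected step from compound 2 to compound 4 is a number 4 percentage points higher from compound 2 to compound 4 (within the scatter).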

Compound 4, a percentage reported as activity, at one concentration (the size of the read-out at that concentration, not a potency): 105%
The estimate for compound 4 lay 5 percentage points below the measured number; low and high end bracket the measured number.
By their numbers in this assay, from the lowest: compound 3; then compounds 2, 4 and 1 (each within the scatter of the next).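

In this assay, the phenyl compound gives this position a reference without a substituent: hydrogen in place of methoxy gives a number 9 percentage points higher from compound 2 to compound 4 (within the scatter) and hydrogen in place of bromo gives a number 1 percentage points lower from compound 1 to compound 4 (within the scatter), so both groups can now be read against hydrogen and not only against each other. Hydrogen, methoxy and bromo on this aromatic carbon thus form a set of three in which no single-point step goes beyond the scatter, and neither substituent shows a measurable effect on the read-out compared with the unsubstituted phenyl, whereas the earlier compounds offered only one exchange of one group for another. No measured evidence is available that would explain this flat result.

The compounds shown leave open whether any group on this aromatic carbon can move the number beyond the scatter in either direction, for example an amine, a carboxylic acid or a longer chain such as ethoxy. They also leave open whether the same flat result would hold for these groups on the other carbons of the six-membered aromatic ring.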